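Series notes: from compound 3 to compound 4

A few compounds are considered here, and "the series" means these few. Any claim that something is new, unique, unknown or untested is made for them only; others in the source may bear on it.

Values so far in a physicochemical assay for lipophilicity, at pH 7.4; a higher number here means a more lipophilic compound, a lower number a more polar compound
compound 1 `Cc1cc(COc2ccc(Cl)cc2)nc(-c2ccccn2)n1` at 3.7
compound 2 `Cc1cc(COc2ccccc2C#N)nc(-c2ccccn2)n1` at 2.7
compound 3 `CC1(CS(C)(=O)=O)CN(c2cc(COc3ccc(F)c(F)c3F)nc(-c3ccccn3)n2)C1` at 2.9

Compound 3 at 2.9 lies within the scatter of compound 2 at 2.7. Against compound 1 at 3.7, compound 3 stands lower on this scale, and that gap is clear of the scatter.

Compound 4 `COC1(COc2cc(COc3ccc(F)c(F)c3F)nc(-c3ccccn3)n2)COC1` carries (3-methoxyoxetan-3-yl)methoxy in place of 3-methyl-3-((methylsulfonyl)methyl)azetidin-1-yl on an aromatic carbon and keeps the (2,3,4-trifluorophenoxy)methyl group and the pyridin-2-yl group.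

Going by the values given here, no measured pair isolates this exchange, so the expectation in this assay has little direct support. A small upward move is expected, estimated as a number 0.30 log units higher from compound 3 to compound 4 (within the scatter) and possibly not clear of the scatter. Among the compounds with values here, the range is kept inside the span from compound 2 at 2.7 to compound 1 at 3.7 as the only guide available. For compound 4 the estimated value is 3.2 with an expected range from 2.8 to 3.6 in this measurement.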

Compound 4, distribution coefficient: 3.5
For compound 4 the middle estimate is 0.30 log units below the measured one, within the range that was stated.
By their numbers in this assay, from the lowest: compounds 2 and 3 (each within the scatter of the next); then compounds 4 and 1 (each within the scatter of the next).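

In this assay, going by these compounds alone, the exchange of 3-methyl-3-((methylsulfonyl)methyl)azetidin-1-yl for (3-methoxyoxetan-3-yl)methoxy on an aromatic carbon gives the first readable step, a number 0.60 log units higher from compound 3 to compound 4 (beyond the scatter). The reading at this position therefore responds to the choice of substituent, even though both groups carry a four-membered non-aromatic ring, the same hydrogen-bond acceptor count, no donors and no net charge. Nothing available ties the step to any one part of the exchange, which alters the linking atom, the ring and the side chain together.

Which of those parts carries the step remains open, as does whether it would recur with another aryl ether in place of the (2,3,4-trifluorophenoxy)methyl group. Also open, going by these compounds, is how this assay would respond at this position to a morpholine, a carboxylic acid or a longer ether chain.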